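The compounds below may be only part of what the source reports. "The series", "measured", "known", "first", "only" and "open" are said of these compounds alone.

Of the compounds shown here, two have so far been tested in a functional assay on RS4-11 cells (Homo sapiens) for inhibition, read by CCK-8 assay, with a stated time of 48 h, tested at 20 uM; on this read-out lower numbers stand for less inhibition of growth and higher numbers for more inhibition of growth at the one concentration tested. Compound 1 `COc1ccc(Cc2nnc(NC(=O)/C(C#N)=C/c3ccccc3OS(=O)(=O)c3ccc(F)cc3)s2)cc1` gives 80%, and compound 2 `N#C/C(=C\c1ccccc1OS(=O)(=O)c1ccc([N+](=O)[O-])cc1)C(=O)Nc1nnc(Cc2cccc3ccccc23)s1` gives 58%. Compound 2 is therefore the lower of the two, and the gap between them lies beyond the usual scatter of this kind of measurement.

The next compound, compound 3 `N#C/C(=C\c1ccccc1OS(=O)(=O)c1ccc(F)cc1)C(=O)Nc1nnc(Cc2cccc3ccccc23)s1`, departs from compound 2 in one place only: fluoro in place of nitro on an aromatic carbon. Put simply, a 4-nitrophenyl becomes a 4-fluorophenyl.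

Within the data shown here, no measured pair shows this change on its own, so the data give no direct size for it. Among the measured compounds shown here, the only hint is that compound 1, at 80%, also carries the 4-fluorophenyl group, and one value is weak support. A modest rise in this assay is therefore expected, and it may not clear the scatter. The expected change is a number 8 percentage points higher from compound 2 to compound 3 (within the scatter). The estimate for compound 3 is 66%, with a likely range from 46% to 84%.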

Compound 3, percent growth inhibition at one concentration: 68%
For compound 3 the middle estimate is 2 percentage points below the measured one; low and high end bracket the measured number.
By their numbers in this assay, from the lowest: compounds 2 and 3 (each within the scatter of the next); then compound 1.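

With fluoro in place of nitro on an aromatic carbon, para to a large group, this assay shows a number 10 percentage points higher from compound 2 to compound 3 (within the scatter), so on this evidence the two groups cannot be told apart at this position, even though the fluoro brings one heavy atom where the nitro brings three. Among these compounds, compound 3 also gives the first pair that differs only on the other side of the molecule: with the 4-fluorophenyl held constant, naphthalen-1-yl in place of 4-methoxyphenyl gives a number 12 percentage points lower from compound 1 to compound 3 (beyond the scatter), a step that does clear the scatter, although it is the only reading of that change. No measurement available here accounts for either step.

Going by these compounds, the nitro and fluoro groups have been compared only with naphthalen-1-yl on the other side, so it remains open whether they would also read alike with 4-methoxyphenyl there. Also open, on these data alone, is how an amine or a carboxylic acid on the same aromatic carbon would read, and whether any of these results would hold at concentrations other than the single one used in this assay.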